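The compounds below may be only part of what the source reports. "The series", "measured", "known", "first", "only" and "open" are said of these compounds alone.

Measured so far:
- compound 1, `Cn1cc(/C=C2/C(=O)Nc3ccccc32)c2cc(Nc3nccc(-c4ccc(O)cc4)n3)ccc21`: 39600 nM
- compound 2, `Cn1cc(/C=C2/C(=O)Nc3ccccc32)c2cc(Nc3nccc(-c4ccc(F)cc4)n3)ccc21`: 48100 nM

In a functional assay on MCF7 cells (Homo sapiens) for cytotoxicity, read by MTT assay, with a stated time of 48 h (on this read-out higher numbers stand for weaker inhibition and lower numbers for stronger inhibition), compound 2 gives the highest of the two numbers shown, with compound 1 nearest to it; the step of a 1.2-fold higher number from compound 1 to compound 2 (0.08 log units; within the scatter) is within the scatter, so the two compounds cannot be ordered on this read-out. For the measured compounds named here, the only structural change measured is fluoro in place of hydroxy on an aromatic carbon, and it moved the number only within the scatter.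

Compound 3, `Cn1cc(/C=C2/C(=O)Nc3ccccc32)c2cc(Nc3nccc(-c4cccs4)n3)ccc21`, has not yet been measured in this assay. It differs from compound 2 as follows: thiophen-2-yl in place of 4-fluorophenyl on an aromatic carbon. The measured step from compound 1 to compound 2 bears on this only loosely, since it swapped one substituent on the same six-membered ring rather than exchanging the whole ring for thiophen-2-yl. With no measured exchange of the ring itself to draw on, the expectation rests on compound 2 alone: the number of compound 3 is expected to stay close to that of compound 2, with an expected step of a 1.1-fold lower number from compound 2 to compound 3 (0.03 log units; within the scatter) not beyond the scatter. Compound 3 is therefore estimated at 45000 nM in this assay, with a range of 15000 nM to 130000 nM.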

Compound 3, half-maximal inhibitory concentration: 30800 nM
Beside the measured number, compound 3's estimate is 1.5-fold (0.16 log units) above it, and the stated range covers the measured number.
By their numbers in this assay, from the lowest: compounds 3, 1 and 2 (each within the scatter of the next).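

Where the earlier step changed only a substituent on the six-membered ring, this one replaces the ring itself at the position next to the ring nitrogen: in this assay the exchange for thiophen-2-yl gives a 1.6-fold lower number from compound 2 to compound 3 (0.19 log units; within the scatter) and, set against the hydroxy-bearing ring, a 1.3-fold lower number from compound 1 to compound 3 (0.11 log units; within the scatter) as well. Neither step leaves the scatter, so on this read-out a five-membered aromatic ring with 1 hetero atom and 5 heavy atoms cannot be told apart from either six-membered carbon ring with 7 heavy atoms, and the three compounds cannot be ordered. The position therefore tolerates a change of ring size and ring atoms without a resolved shift in the number, although nothing available speaks to what lies behind these small differences. Still open, from the compounds shown here alone, is whether this position can move the number beyond the scatter at all, for instance with an amine such as morpholine or with a carboxylic acid on the ring. Also open is how far changes elsewhere on the shared core would matter, since every step shown here falls at this one position.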